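The source may report more compounds than this note shows. Statements on the series, on what has been measured and on what is new or still open speak of the compounds shown alone.

Measured in an ADME assay on microsomes from liver (Rattus norvegicus) for metabolic stability, read by LC-MS, using NADPH, with a stated time of 30 min, tested at 0.1 uM, in the presence of a further agent that is not named here; on this read-out lower numbers stand for a less stable compound and higher numbers for a more stable compound
compound 1 `Nc1ccc(-c2cnc(N)c(-c3ccc(N)nc3)n2)cn1` gives > 90%
compound 2 `NC(=O)c1ccc(-c2cnc(N)c(-c3ccc(C(F)(F)F)cc3)n2)cc1` gives > 90%
compound 3 `Nc1ccc(-c2nc(-c3ccc(S(=O)(=O)C4CC4)cc3)cnc2N)cn1` gives > 90%

Each of these entries is a limit of the assay and not a number. Compound 2 stands at > 90%, which is a limit. Among the measured compounds shown here, the series so far shows (the limit of > 90% in this assay, at which 3 of the 3 values shown sit). Compound 4 `Nc1ncc(-c2ccc(C(=O)O)cc2)nc1-c1ccc(C(F)(F)F)cc1` differs from compound 2 by hydroxy in place of amino on a carbonyl carbon, which reads as carbamoyl to carboxy. For the measured compounds named here, no step between measured compounds is available to size this change. The estimated step that the limit leaves unreadable from compound 2 to compound 4 is expected to stay within the usual scatter, with no direction favoured. In this assay compound 4 is estimated at 93%, with an expected range from 78% to 100%.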

Compound 4, percent of the compound remaining: > 90%
Compound 4 gave a limit, no number (the forecaster's own chance of this, stated with the estimate: 70%); the middle value is on the limit's open side.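

No new step can be read between compound 2 and compound 4, because both values are limits and not numbers: the limit of > 90% in this assay, at which 4 of the 4 values shown sit.

Whether carbamoyl to carboxy shifts the percent remaining at all, and how the compounds shown rank against one another, stays open.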